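A few compounds are considered here, and "the series" means these few. Any claim that something is new, unique, unknown or untested is made for them only; others in the source may bear on it.

Measured in a physicochemical assay for solubility, read by HPLC, in phosphate buffer, measured as kinetic solubility, at pH 7.4; a higher number here means a more soluble compound, a lower number a less soluble compound:
- compound 1 `CCC(=O)c1cc(-c2ccc(OC)cc2)n(-c2ccc(S(N)(=O)=O)cc2)c1C`: 12800 nM
- compound 2 `CCC(=O)c1cc(-c2ccc(C)cc2)n(-c2ccc(S(N)(=O)=O)cc2)c1C`: 1000 nM

Compound 2, at 1000 nM, has the lower of the two numbers in this assay. The next compound, compound 3 `CCC(=O)c1cc(-c2ccc(Cl)cc2Cl)n(-c2ccc(S(N)(=O)=O)cc2)c1C`, carries 2,4-dichlorophenyl in place of 4-methylphenyl on an aromatic carbon, next to the ring nitrogen: 2,4-dichlorophenyl in place of 4-methylphenyl on an aromatic carbon.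

Among the compounds with values here, only one measured step bears on this change. That step, a 13-fold lower number from compound 1 to compound 2 (1.11 log units; beyond the scatter), is large, but it exchanges a different pair of groups, so it gives no direct measure of the size to expect here. It does show that a single exchange in this series can move the number far beyond the scatter. The direction expected here rests on that one step alone, and the support is weak.

The expected step is a 2.2-fold lower number from compound 2 to compound 3 (0.35 log units; beyond the scatter), a modest move to a lower number. For compound 3 the estimated value is 450 nM, with an expected range from 100 nM to 2000 nM.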

Compound 3, solubility: 7700 nM
The estimate for compound 3 lay 17-fold (1.23 log units) below the measured number; the measured number lies above the stated range.
By their numbers in this assay, from the lowest: compound 2; then compounds 3 and 1 (each within the scatter of the next).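

At this position on the shared core, an aromatic carbon next to the ring nitrogen, the exchange moves the number in this assay upward, with a 7.7-fold higher number from compound 2 to compound 3 (0.89 log units; beyond the scatter) and so compound 2 stands alone as the lowest of the three. Two different groups, 4-methoxyphenyl and 2,4-dichlorophenyl, give numbers that cannot be told apart, with a 1.7-fold lower number from compound 1 to compound 3 (0.22 log units; within the scatter) and so among these compounds only 4-methylphenyl stands apart. Nothing here accounts for why the number rises with this change.

On these data alone, compound 3 differs from compound 2 by two chlorines and the loss of a methyl group, so the share of each change remains open; 4-chlorophenyl would help separate them. Also open, as far as these compounds go, is how an amine or a carboxylic acid on this phenyl ring, or a longer chain in place of the propanoyl group, would behave.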